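Carboxy for Chloro on the Phenyl Ring of Compound 2

The source may hold more compounds than are shown below. What is called first, only, known or untested is meant among the compounds shown, and "the series" means these compounds.

Compound 2 `Cc1csc(NC(=O)Cn2cc(-c3ccc(Cl)cc3)nn2)n1` gives 520 nM in a functional assay on BMDM cells (Mus musculus, strain C57BL/6) for inhibition, with a stated time of 2 days (on this read-out higher numbers stand for weaker inhibition and lower numbers for stronger inhibition), the highest of the three numbers recorded there. Compound 1 `Cc1csc(NC(=O)Cn2cc(-c3cccc(N)c3)nn2)n1` gives 250 nM, and compound 3 `CCOC(=O)c1sc(NC(=O)Cn2cc(-c3ccc(Cl)cc3)nn2)nc1C` gives 180 nM. The step of a 2.1-fold higher number from compound 1 to compound 2 (0.32 log units; beyond the scatter) and the step of a 2.9-fold lower number from compound 2 to compound 3 (0.46 log units; beyond the scatter) both sit beyond the scatter, so compound 2 is the weakest of the measured set. Compound 4 `Cc1csc(NC(=O)Cn2cc(-c3ccc(C(=O)O)cc3)nn2)n1` differs from compound 2 by carboxy in place of chloro on an aromatic carbon. Of the measured steps, only the change between compound 1 and compound 2 touches the same ring, and that step was modest, so a modest lowering of the number is expected, with the step of a 1.7-fold lower number from compound 2 to compound 4 (0.24 log units; within the scatter). Compound 4 is therefore estimated at 300 nM, in a range from 100 nM to 900 nM.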

Compound 4, half-maximal inhibitory concentration: > 30000 nM
Compound 4: only a limit was reported; the forecaster's own chance of this, stated with the estimate: 5%; at least 100-fold (2.00 log units) between middle value and limit.
By their numbers in this assay, from the lowest: compounds 3 and 1 (each within the scatter of the next); then compound 2. At a limit, above all of these: compound 4.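

In this assay, carboxy in place of chloro on this aromatic carbon gives an at least 57-fold higher number from compound 2 to compound 4 (1.76 log units; beyond the scatter), a large step, whereas the earlier change on the same ring, a 2.1-fold higher number from compound 1 to compound 2 (0.32 log units; beyond the scatter), was modest. Compound 4 has only a limit: the limit of > 30000 nM in this assay, at which 1 of the 4 values shown sits.

This position therefore does not take every group with a modest change, which compounds 1 and 2 alone could not show. The compounds shown leave open whether a methyl ester, a primary amide or a nitrile at this place would behave like carboxy or like chloro. They also leave open whether the ethoxycarbonyl of compound 3 would change the outcome with carboxy on the ring.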